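A few compounds are considered here, and "the series" means these few. Any claim that something is new, unique, unknown or untested is made for them only; others in the source may bear on it.

Measured compounds in a functional assay on HT-29 cells (Homo sapiens) for inhibition, read by MTT assay, with a stated time of 48 h; on this read-out higher numbers stand for weaker inhibition and lower numbers for stronger inhibition:

- compound 1 `Cc1ccc(NC(=O)NC(=O)c2ccc(OCc3ccccc3)cc2)cc1-c1nc2ccccc2[nH]1`: 16400 nM
- compound 2 `Cc1ccc(NC(=O)NC(=O)c2ccc(OCc3cccc(Cl)c3)cc2)cc1-c1nc2ccccc2[nH]1`: 15400 nM
- compound 3 `Cc1ccc(COc2ccc(C(=O)NC(=O)Nc3ccc(C)c(-c4nc5ccccc5[nH]4)c3)cc2)cc1`: 5110 nM

Compound 3 gives the lowest number of the three: the step of a 3.2-fold lower number from compound 1 to compound 3 (0.51 log units; beyond the scatter) and the step of a 3.0-fold lower number from compound 2 to compound 3 (0.48 log units; beyond the scatter) both lie beyond the scatter, whereas the step of a 1.1-fold lower number from compound 1 to compound 2 (0.03 log units; within the scatter) does not.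

Compound 4 `Cc1ccc(COc2ccc(C(=O)NC(=O)Nc3ccc(Cl)c(-c4nc5ccccc5[nH]4)c3)cc2)cc1` differs from compound 3 by chloro in place of methyl on an aromatic carbon. Among the measured compounds shown here, none of the measured steps changes this ring: the chloro-for-hydrogen step a 1.1-fold lower number from compound 1 to compound 2 (0.03 log units; within the scatter) and the methyl-for-hydrogen step a 3.2-fold lower number from compound 1 to compound 3 (0.51 log units; beyond the scatter) both concern the ring at the far end of the molecule, and the exchange of one of those rings for the other, a 3.0-fold lower number from compound 2 to compound 3 (0.48 log units; beyond the scatter), is of modest size. For the measured compounds named here, no measured pair shows what a chloro in place of methyl does on the ring that carries the benzimidazolyl group, so the only guide is that the one chloro-for-hydrogen exchange seen, a 1.1-fold lower number from compound 1 to compound 2 (0.03 log units; within the scatter), stayed within the scatter.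

On that basis compound 4 is expected to stay close to compound 3, with the step of a 1.1-fold higher number from compound 3 to compound 4 (0.03 log units; within the scatter) estimated to fall within the scatter. The estimate for compound 4 in this assay is therefore 5500 nM, with a range from 2000 nM to 15000 nM.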

Compound 4, half-maximal inhibitory concentration: 2950 nM
Compound 4: middle estimate off by 1.9-fold (0.27 log units), on the high side; the measured number falls inside the stated range.
By their numbers in this assay, from the lowest: compounds 4 and 3 (each within the scatter of the next); then compounds 2 and 1 (each within the scatter of the next).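

In this assay, the position ortho to a 1H-benzimidazol-2-yl group and para to a large group now has its first direct reading: chloro in place of methyl gives a 1.7-fold lower number from compound 3 to compound 4 (0.24 log units; within the scatter), so the read-out does not separate these two substituents here. The earlier steps shown here all lay on the ring at the far end of the molecule, so they said nothing about this place; compound 4 shows that the exchange at this position, with the 4-methylphenyl end held fixed, leaves the number within the usual spread of repeats. No measurement at hand explains the size of this step.

Only methyl and chloro appear at this position in the compounds shown, so what hydrogen, a methoxy group, an amine or a carboxylic acid would give there remains open. Also open, on these data alone, is whether chloro at this position gives a similar step when the far end carries the unsubstituted phenyl of compound 1 or the 3-chlorophenyl of compound 2.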